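From furan-2-yl to 6-amino-5-methylpyridin-3-yl: an expected step

A few compounds are considered here, and "the series" means these few. Any claim that something is new, unique, unknown or untested is made for them only; others in the source may bear on it.

The compounds share the core of compound 1 `Nc1nc(-c2ccc(Cl)cc2)c(CC(=O)O)s1`, which carries a carboxymethyl group on one ring carbon. In an in vitro functional assay on HEK285-7 cells for antagonist activity at prostaglandin D2 receptor 2 (Homo sapiens), read by BRET and beta-arrestin recruitment (a higher number here means a weaker inhibitor, a lower number a stronger inhibitor), compound 1 gives > 100000 nM, a limit of the assay rather than a number (the limit of > 100000 nM in this assay, at which 1 of the 3 values shown sits). Compound 2 `O=C(O)Cc1sc(C(c2ccccc2)c2ccc(Cl)cc2)nc1-c1ccc(Cl)cc1` gives 75 nM in this assay, and compound 3 `O=C(O)Cc1sc(C(c2ccc(F)cc2)c2ccc(F)cc2)nc1-c1ccco1` gives 140 nM, the higher of the two numbers, though its gap to compound 2 lies within the scatter. Compound 4 `Cc1cc(-c2nc(C(c3ccc(F)cc3)c3ccc(F)cc3)sc2CC(=O)O)cnc1N` has not yet been measured; it differs from compound 3 in one place (6-amino-5-methylpyridin-3-yl in place of furan-2-yl on an aromatic carbon). For the measured compounds named here, no step of this kind has been measured, so the expectation rests on compound 3 alone. A modest gain is expected, a 1.6-fold lower number from compound 3 to compound 4 (0.19 log units; within the scatter), though the change could also remain within the scatter. Compound 4 is estimated at 90 nM, in a range from 30 nM to 300 nM.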

Compound 4, half-maximal inhibitory concentration: > 100000 nM
Compound 4 ended at the assay's limit (the forecaster's own chance of this, stated with the estimate: 3%); middle value at least 1100-fold (3.04 log units) away from the limit.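

In this assay, 6-amino-5-methylpyridin-3-yl in place of furan-2-yl next to the ring nitrogen gives an at least 710-fold higher number from compound 3 to compound 4 (2.85 log units; beyond the scatter), the first single-place step shown. This position therefore does not accept every aromatic ring: activity survives with furan-2-yl but is lost with this substituted six-membered ring. Compound 4 stands at a limit of the assay, not a number, so only a minimum size of the step can be read: the limit of > 100000 nM in this assay, at which 2 of the 4 values shown sit.

As far as these compounds go, whether the loss follows the amine, the methyl or the ring nitrogen stays open. A plain pyridin-3-yl at this same place would begin to separate them.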